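The source may hold more compounds than are shown below. What is called first, only, known or untested is meant among the compounds shown, and "the series" means these compounds.

Three esters and one acid built on the core of compound 1 `CCOc1ccc(-c2cccc(C(=O)O)c2)cc1` have been tested. In an assay on COS-7 cells for inhibition of patatin-like phospholipase domain-containing protein 2 (Mus musculus) (on this read-out higher numbers stand for weaker inhibition and lower numbers for stronger inhibition), compound 1 gives only a limit of the assay, > 200000 nM. Compound 2 `CCOc1ccc(-c2cccc(C(=O)OCCOC)c2)cc1` gives 70000 nM in this assay. Compound 3 `CCOc1ccc(-c2cccc(C(=O)OCC(F)(F)F)c2)cc1` gives 120000 nM in this assay, which is the higher of the two numbers; its nearest neighbour is compound 2, and the gap a 1.7-fold higher number from compound 2 to compound 3 (0.23 log units; within the scatter) stays inside the scatter. Against the acid, the steps are an at least 2.8-fold lower number from compound 1 to compound 2 (0.45 log units; beyond the scatter) and an at least 1.6-fold lower number from compound 1 to compound 3 (0.22 log units; that floor lies within the scatter), the latter with a floor still within the scatter, so both esters read as no more than modestly stronger than the acid.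

Compound 4 `CCOc1ccc(-c2cccc(C(=O)OCCOCCOC)c2)cc1` carries the change ((2-methoxyethoxy)methyl in place of trifluoromethyl on a saturated chain carbon bound to an oxygen next to a carbonyl group). For the measured compounds named here, the only measured step at that position, a 1.7-fold higher number from compound 2 to compound 3 (0.23 log units; within the scatter), was within the scatter, and the whole set spans a narrow band. Going by the values given here, the new ester extends the chain of compound 2 by one further ether unit, for which no measured step exists. Compound 4 is therefore expected to give a number close to those of the two esters, with a 1.7-fold lower number from compound 3 to compound 4 (0.23 log units; within the scatter) as the estimated step, most likely no more than a modest lowering. The estimate for compound 4 in this assay is 70000 nM, with a range from 25000 nM to 200000 nM.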

Compound 4, half-maximal inhibitory concentration: > 200000 nM
Compound 4 gave a limit, no number; the forecaster's own chance of this, stated with the estimate: 20%; middle value at least 2.8-fold (0.45 log units) from the limit.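

In this assay, for the compounds shown here, the change at this position finally produces a step that clears the scatter: the one further ether unit gives an at least 2.8-fold higher number from compound 2 to compound 4 (0.45 log units; beyond the scatter), whereas the only earlier step between esters stayed inside it. Lengthening 2-methoxyethyl to 2-(2-methoxyethoxy)ethyl therefore weakens the reading at least modestly, while replacing 2,2,2-trifluoroethyl with 2-(2-methoxyethoxy)ethyl gives an at least 1.6-fold higher number from compound 3 to compound 4 (0.22 log units; that floor lies within the scatter), whose floor lies within the scatter and so does not separate these two esters firmly. Compound 1 and compound 4 both sit at a limit, so the step between them cannot be read: the limit of > 200000 nM in this assay, at which 2 of the 4 values shown sit.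

The compounds shown leave open whether the weaker reading goes with the length of the chain or with its added ether oxygen, a question that an all-carbon chain of the same length could separate. They also leave open how an amine at the end of the chain, or an amide in place of the ester, would read on the core of compound 1.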